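Changing the acyl group of compound 2

The source may hold more compounds than are shown below. What is called first, only, known or untested is meant among the compounds shown, and "the series" means these compounds.

Compound 1 `COc1cccc(Nc2nc3c(c(Oc4cccc(NC(=O)C=C(C)C)c4)n2)CSCC3)c1` gives 19100 nM
Compound 2 `C/C=C/C(=O)Nc1cccc(Oc2nc(Nc3ccc(OC)cc3)nc3c2CSCC3)c1` gives > 50000 nM as a limit
Compound 3 `COc1ccc(Nc2nc3c(c(Oc4cccc(NC(=O)C=C(C)C)c4)n2)CSCC3)cc1` awaits measurement

In a functional assay on HeLa cells (Homo sapiens) for antiproliferative activity, read by MTT assay, with a stated time of 72 h (on this read-out lower numbers stand for stronger inhibition and higher numbers for weaker inhibition), compound 2 reads > 50000 nM as a limit of the assay and not a number. Compound 3 differs from compound 2 by a single change (2-methylprop-1-en-1-yl in place of prop-1-en-1-yl on a carbonyl carbon) with 2-methylprop-1-en-1-yl in place of prop-1-en-1-yl on a carbonyl carbon. Among the measured compounds shown here, no measured pair shows this change alone. Compound 1 carries the same 2-methylprop-1-en-1-yl group and gives 19100 nM in this assay and this points to a modest move toward stronger inhibition. The expected step is an at least 1.6-fold lower number from compound 2 to compound 3 (0.22 log units; that floor lies within the scatter) and it may prove small. For compound 3 the estimated value is 30000 nM (expected range 12000 nM to 50000 nM).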

Compound 3, half-maximal inhibitory concentration: 19100 nM
Estimate against measurement, compound 3: 1.6-fold (0.20 log units) above; measured number inside the range.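

In this assay, 2-methylprop-1-en-1-yl in place of prop-1-en-1-yl on a carbonyl carbon gives an at least 2.6-fold lower number from compound 2 to compound 3 (0.41 log units; beyond the scatter) as the only pair shown with this change alone. From the compounds shown here alone, compound 2 stands at a limit of the assay and not a number, so the full size of this step stays open: the limit of > 50000 nM in this assay, at which 1 of the 3 values shown sits. With 2-methylprop-1-en-1-yl in place, 4-methoxyphenyl in place of 3-methoxyphenyl on a nitrogen on an aromatic ring gives no change at the digits printed from compound 1 to compound 3 (within the scatter) in this pair.

Going by these compounds, whether the acyl step holds with 3-methoxyphenyl on that nitrogen remains open. So does how an amine or a longer chain on the carbonyl carbon would read.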